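The compounds below may be only part of what the source reports. "The series", "measured", "known", "first", "only" and "open" are said of these compounds alone.

Compound 1 `Clc1ccccc1-c1n[nH]cc1N1CCNCC1`: > 10000 nM
Compound 2 `Clc1cccc(-c2n[nH]cc2N2CCNCC2)c1`: > 10000 nM
Compound 3 `Fc1ccccc1-c1n[nH]cc1N1CCNCC1`: > 10000 nM

In an assay on isolated protein for binding affinity to 5-hydroxytryptamine receptor 1D (Homo sapiens) (a lower number here means a stronger inhibitor, a higher number a weaker inhibitor), compound 1 gives > 10000 nM, which is a limit of the assay and not a number. Compound 2 gives > 10000 nM, again a limit. Compound 3 gives > 10000 nM, also a limit. The step from compound 1 to compound 3 is a step that the two limits leave unreadable from compound 1 to compound 3; the change behind it is fluoro in place of chloro on an aromatic carbon, and its size stays unreadable because the limit of > 10000 nM in this assay, at which 3 of the 3 values shown sit, holds all three values. Compound 2 has the same atoms as compound 1, joined differently; the difference between the two cores is not broken down here.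

Compound 4 `Fc1cccc(-c2n[nH]cc2N2CCNCC2)c1` is not yet measured. It differs from compound 2 by fluoro in place of chloro on an aromatic carbon. This is the same kind of change as that from compound 1 to compound 3, but the surroundings differ: there the new group sits ortho to a large group, here meta to a large group. Within the data shown here, since every value so far sits at the limit of > 10000 nM in this assay, at which 3 of the 3 values shown sit, the step from compound 2 to compound 4 is expected to be a step that the limit leaves unreadable from compound 2 to compound 4. Compound 4 is therefore estimated at 20000 nM, most likely between 8000 nM and 60000 nM, and quite possibly only as a limit.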

Compound 4, inhibition constant: 911 nM
The estimate for compound 4 lay 22-fold (1.34 log units) above the measured number; the whole stated range lies above it.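

In this assay, putting fluoro in place of chloro meta to a large group gives an at least 10-fold lower number from compound 2 to compound 4 (1.04 log units; beyond the scatter), and since compound 2 stands at a limit, the true step could be larger still. The same swap cannot be read from compound 1 to compound 3, because both values sit at a limit of the assay: the limit of > 10000 nM in this assay, at which 3 of the 4 values shown sit. So the change clearly pays off in one setting, but nothing shows that it carries over to the other: compound 3 may have gained something that stays hidden behind its limit, or it may have gained nothing, and the cause of the drop in compound 4 remains unknown.

The compounds shown leave open whether the gain belongs to fluoro itself, since no other group appears in that place. A methoxy or a nitrile in place of the fluoro of compound 4 would help to tell how specific this result is.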